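A few compounds are considered here, and "the series" means these few. Any claim that something is new, unique, unknown or untested is made for them only; others in the source may bear on it.

Compound 1 `COc1ccc2c(=O)c(/C=C/C(=O)Nc3cccc(C)c3)coc2c1` carries a 3-methylphenyl group on its amide nitrogen. In a functional assay on A549 cells (Homo sapiens) for inhibition, read by MTT assay, with a stated time of 48 h (a lower number here means a stronger inhibitor, a higher number a weaker inhibitor), compound 1 gives > 100000 nM, and this is a limit of the assay rather than a number (the limit of > 100000 nM in this assay, at which 1 of the 3 values shown sits). Compound 2 `COc1ccc2c(=O)c(/C=C/C(=O)Nc3ccccc3)coc2c1` gives 51000 nM in this assay, and compound 3 `COc1ccc2c(=O)c(/C=C/C(=O)Nc3ccc(F)cc3)coc2c1` gives 26800 nM. The change that removes the methyl gives an at least 1.9-fold lower number from compound 1 to compound 2 (0.29 log units; that floor lies within the scatter), while the exchange for a 4-fluorophenyl gives an at least 3.7-fold lower number from compound 1 to compound 3 (0.57 log units; beyond the scatter); between the two smaller compounds the step is a 1.9-fold lower number from compound 2 to compound 3 (0.28 log units; within the scatter). Compound 1 therefore stands as the weakest of the three, though only its limit is known.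

Compound 4 `COc1ccc2c(=O)c(/C=C/C(=O)Nc3ccc(C)cc3)coc2c1` differs from compound 1 by 4-methylphenyl in place of 3-methylphenyl on an amide-type nitrogen. The steps from compound 1 to compound 2 and to compound 3 bear on this change: both moves away from the 3-methylphenyl lowered the number, and the one that placed a substituent at the 4-position did so beyond the scatter. Compound 4 is therefore expected to give a lower number than compound 1 in this assay, with the step estimated at an at least 2.0-fold lower number from compound 1 to compound 4 (0.30 log units; that floor lies within the scatter). The estimate for compound 4 in this assay is 50000 nM, expected to lie between 20000 nM and 130000 nM.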

Compound 4, half-maximal inhibitory concentration: 17500 nM
Compound 4: the middle estimate sits 2.9-fold (0.46 log units) above what was measured; the whole stated range lies above it.
By their numbers in this assay, from the lowest: compounds 4, 3 and 2 (each within the scatter of the next, the first and the last beyond it). At a limit, above all of these: compound 1.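

Exchanging the 3-methylphenyl for the 4-methylphenyl on the amide-type nitrogen leaves the atoms the same and joins them differently, yet it gives an at least 5.7-fold lower number from compound 1 to compound 4 (0.75 log units; beyond the scatter) in this assay, so among these compounds the place of the methyl on the ring counts, and not only its presence. This step is a floor, since compound 1 stands at a limit and not at a number: the limit of > 100000 nM in this assay, at which 1 of the 4 values shown sits.

Against the unsubstituted phenyl, the 4-methylphenyl gives a 2.9-fold lower number from compound 2 to compound 4 (0.46 log units; beyond the scatter), the first step from compound 2 that clears the scatter with a measured value at each end, while the exchange of fluoro for methyl gives a 1.5-fold lower number from compound 3 to compound 4 (0.19 log units; within the scatter), which leaves the 4-fluorophenyl and the 4-methylphenyl not told apart.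

What the compounds shown leave open is whether a methoxy group, a chlorine or an amine in place of that methyl would give a lower number still, or whether a longer chain such as ethyl would keep the gain. From the compounds shown here alone, the true size of the step from compound 1 also stays open, as does whether the pattern holds for any other group on this ring.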